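Amide carbonyl substituent swap on a shared azetidine series

The source may hold more compounds than are shown below. What is called first, only, known or untested is meant among the compounds shown, and "the series" means these compounds.

Measured so far:
compound 1 `Cc1cccc(-c2noc(C3CN(C(=O)C4CCC(C(F)(F)F)CC4)C3)n2)c1` gives 1000 nM
compound 2 `O=C(C1CCCCC1)N1CC(c2nc(-c3cccc(F)c3)no2)C1` gives 1000 nM
compound 3 `O=C(C1CCC2(CCC2)CC1)N1CC(c2nc(-c3cccc(Cl)c3)no2)C1` gives 1100 nM

Three compounds have been run in an assay on HEK293 cells for positive allosteric modulation of metabotropic glutamate receptor 5 (Homo sapiens), read by FLIPR (a higher number here means that more compound is needed for the effect, a lower number that less compound is needed), all sharing the same core and differing in the aromatic substituent and in the group on the carbonyl carbon. Compound 3 cannot be told apart from its companions on these numbers: its gap to compound 1 and its gap to compound 2 both lie within the scatter of repeated measurements, so the three stand together rather than in any order.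

Compound 4 `O=C(N1CCCCCC1)N1CC(c2nc(-c3cccc(Cl)c3)no2)C1` is the next member, and it differs from compound 3 in one place: a group of 7 heavy atoms (6 carbon, 1 nitrogen; one seven-membered non-aromatic ring with 1 hetero atom) in place of a group of 9 heavy atoms (9 carbon; one four-membered non-aromatic ring of carbon only, one six-membered non-aromatic ring of carbon only), on a carbonyl carbon

Within the data shown here, no step between two measured compounds isolates a change of this kind on the carbonyl carbon, so there is nothing in the measured set to lean on for direction. Given that the three measured compounds sit so close to one another despite their different carbonyl substituents, compound 4 is expected to stay near them, with the step from compound 3 estimated as a 1.1-fold higher number from compound 3 to compound 4 (0.04 log units; within the scatter), that is, none beyond the scatter. Compound 4 is therefore estimated at 1200 nM in this assay, with a range from 400 nM to 4000 nM.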

Compound 4, half-maximal effective concentration: 47 nM
Beside the measured number, compound 4's estimate is 26-fold (1.41 log units) above it, and the stated range ends above it.
By their numbers in this assay, from the lowest: compound 4; then compounds 1, 2 and 3 (each within the scatter of the next).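

In this assay, azepan-1-yl in place of the carbon-only group with its four-membered and six-membered rings gives a 23-fold lower number from compound 3 to compound 4 (1.37 log units; beyond the scatter), on a carbonyl carbon whose other neighbours are amide-type nitrogen in a ring. Among these compounds, this is the first change in the set made in one place only, and it shows that the group at this position can move the number well beyond the scatter, which the close values of compounds 1, 2 and 3 gave no sign of, as those compounds differ from one another in more than one place. Nothing measured here accounts for the size of this step.

The swap alters the ring nitrogen, the ring size and the number of rings together, so the compounds shown leave open which of these carries the step, and a cycloheptyl group or a piperidin-1-yl group on the same carbonyl carbon would begin to pull them apart. From the compounds shown here alone, it also remains open whether azepan-1-yl would give a step of similar size with the other aromatic substituents in the set, the fluorine of compound 2 or the methyl of compound 1.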